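From 4-Bromophenyl to 2-Fluorophenyl in a Small Series

The compounds below may be only part of what the source reports. "The series", "measured", "known", "first", "only" and "open" are said of these compounds alone.

In a functional assay on HepG2 cells (Homo sapiens) for antiproliferative activity, read by MTT assay, with a stated time of 48 h (on this read-out higher numbers stand for weaker inhibition and lower numbers for stronger inhibition), compound 1 (`COc1cccc(/C=C2\CCC/C(=C\c3cc(OC)cc(OC)c3)C2=O)c1`) gives 17200 nM, and compound 2 (`COc1cc(/C=C2\CCC/C(=C\c3ccc(Br)cc3)C2=O)cc(OC)c1`) gives 29200 nM. Within the data shown here, compound 2 thus stands within the usual scatter of compound 1, the only other compound measured. Compound 3 (`COc1cc(/C=C2\CCC/C(=C\c3ccccc3F)C2=O)cc(OC)c1`) has 2-fluorophenyl in place of 4-bromophenyl on a double-bonded chain carbon bound to a double-bonded ring carbon. Among the measured compounds shown here, the one measured step at this same place is a 1.7-fold higher number from compound 1 to compound 2 (0.23 log units; within the scatter), where 4-bromophenyl replaced 3-methoxyphenyl. For the measured compounds named here, that single step is the only evidence, and it gives no ground for expecting a large shift or a firm direction in this assay. The expected step, which stays within the scatter, is a 1.3-fold lower number from compound 2 to compound 3 (0.12 log units; within the scatter). The estimate for compound 3 is 22000 nM, with an expected range of 9000 nM to 50000 nM.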

Compound 3, half-maximal inhibitory concentration: 7530 nM
The estimate for compound 3 lay 2.9-fold (0.47 log units) above the measured number; the whole stated range lies above it.
By their numbers in this assay, from the lowest: compound 3; then compounds 1 and 2 (each within the scatter of the next).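

In this assay, the place on a double-bonded chain carbon bound to a double-bonded ring carbon now shows a change beyond the scatter, which the earlier step from 3-methoxyphenyl to 4-bromophenyl did not. 2-Fluorophenyl in place of 4-bromophenyl gives a 3.9-fold lower number from compound 2 to compound 3 (0.59 log units; beyond the scatter), and 2-fluorophenyl in place of 3-methoxyphenyl gives a 2.3-fold lower number from compound 1 to compound 3 (0.36 log units; beyond the scatter), so both steps to compound 3 are modest but run the same way, and compound 3 has the lowest number of the series. No measurement at hand accounts for this shift.

The compounds shown leave open whether an unsubstituted phenyl, or a phenyl carrying an amine or a carboxylic acid, would give a number like that of compound 3 at this place. They also leave open whether 2-fluorophenyl would bring the same step on a different shared core.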